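The source may report more compounds than this note shows. Statements on the series, on what has been measured and on what is new or still open speak of the compounds shown alone.

Values in an ADME assay on microsomes from liver (Rattus norvegicus, strain Sprague-Dawley) for metabolic stability, read by HPLC, using NADPH, with stated times of 5 min and 60 min, tested at 10 uM (on this read-out lower numbers stand for slow clearance and higher numbers for fast clearance), for the series so far:
compound 1 `CN(C)c1ccc(C(=O)NCc2ccc(NS(C)(=O)=O)cc2Cl)cc1` gives 25 mL.min-1.g-1
compound 2 `CS(=O)(=O)Nc1ccc(CNC(=O)c2ccc(N3CCCCC3)cc2)c(Cl)c1` gives 20 mL.min-1.g-1
compound 3 `CC(C)(O)c1ccc(C(=O)NCc2ccc(NS(C)(=O)=O)cc2Cl)cc1` gives 1.5 mL.min-1.g-1

Compound 3 is the lowest of the three. Both steps leading to it are large: a 17-fold lower number from compound 1 to compound 3 (1.22 log units; beyond the scatter) and a 13-fold lower number from compound 2 to compound 3 (1.12 log units; beyond the scatter) each replace an amino group with 1-hydroxy-1-methylethyl. By contrast, a 1.3-fold lower number from compound 1 to compound 2 (0.10 log units; within the scatter) stays within the scatter, so dimethylamino and piperidin-1-yl cannot be told apart here.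

Compound 4 `CS(=O)(=O)Nc1ccc(CNC(=O)c2ccc(CC(F)(F)F)cc2)c(Cl)c1` carries 2,2,2-trifluoroethyl in place of 1-hydroxy-1-methylethyl on an aromatic carbon, para to a large group. The count reads 2,2,2-trifluoroethyl in place of 1-hydroxy-1-methylethyl on an aromatic carbon for this change. Within the data shown here, no measured compound carries 2,2,2-trifluoroethyl, so no measured step covers this change directly. The two large steps show only that the low number of compound 3 goes with 1-hydroxy-1-methylethyl among these three compounds, and compound 4 gives that group up. In this assay a rise beyond the scatter is therefore expected, but a smaller one than those two large steps, as the entering group is neither amino group. The expected size is a 4.0-fold higher number from compound 3 to compound 4 (0.60 log units; beyond the scatter) in this estimate. For compound 4 the estimated value is 6 mL.min-1.g-1 with an expected range from 2.5 mL.min-1.g-1 to 15 mL.min-1.g-1 for the measurement.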

Compound 4, intrinsic clearance in microsomes: 22 mL.min-1.g-1
The estimate for compound 4 lay 3.7-fold (0.56 log units) below the measured number, outside the stated range (above it).
By their numbers in this assay, from the lowest: compound 3; then compounds 2, 4 and 1 (each within the scatter of the next).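

In this assay the step to the trifluoroethyl group is large, with a 15-fold higher number from compound 3 to compound 4 (1.17 log units; beyond the scatter) at this place on an aromatic carbon, para to a large group, so a high number here does not need an amino group. The new compound also sits level with both amino compounds: a 1.1-fold higher number from compound 2 to compound 4 (0.04 log units; within the scatter) and a 1.1-fold lower number from compound 1 to compound 4 (0.06 log units; within the scatter) both stay within the scatter, leaving compound 1, compound 2 and compound 4 impossible to tell apart despite the different groups they carry. Among the four compounds, the low number now stands with 1-hydroxy-1-methylethyl alone, and compound 3 is the only one set apart by a step beyond the scatter.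

Still open, going by these compounds, is which part of 1-hydroxy-1-methylethyl goes with the low number: tert-butyl would keep the branched carbons without the oxygen, while hydroxymethyl would keep the oxygen on a shorter chain. Among these compounds, nothing measured so far accounts for the gap between compound 3 and the other three compounds.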